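A few compounds are considered here, and "the series" means these few. Any claim that something is new, unique, unknown or untested is made for them only; others in the source may bear on it.

Compound 1 `O=C(/C=C/c1ccc([N+](=O)[O-])o1)c1ccc(I)cc1` carries an iodo group on its outer ring. In an ADME assay on Vero cells (Chlorocebus sabaeus) for cytotoxicity, read by resazurin assay, with a stated time of 72 h (a higher number here means that more compound is tolerated, a lower number that less compound is tolerated), compound 1 gives only a limit of the measurement, > 100000 nM, rather than a number. For comparison, compound 2 `Cc1ccccc1C(=O)/C=C/c1ccc([N+](=O)[O-])o1` gives 41300 nM in this assay. Compound 3 `O=C(/C=C/c1ccco1)c1ccc(N2CCCCC2)cc1` has "not determined" (no result reported) in this assay. Compound 1 thus stands at the limit of > 100000 nM in this assay, at which 1 of the 3 values shown sits, the upper edge of what the readings reach. Compound 4 `O=C(/C=C/c1ccc([N+](=O)[O-])o1)c1ccc(Br)cc1` differs from compound 1 in one place: bromo in place of iodo on an aromatic carbon. Within the data shown here, no measured pair shows what this change does, so in this assay the step is expected to be small, within the usual scatter, in either direction. Compound 4 is therefore expected to give about 100000 nM, in a range from 35000 nM to 300000 nM. The step of a number no higher from compound 1 to compound 4 (the limit leaves the size open) is expected to be no larger than the scatter.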

Compound 4, half-maximal cytotoxic concentration: > 100000 nM
Compound 4 ended at the assay's limit (the forecaster's own chance of this, stated with the estimate: 50%); the middle value lies on the limit itself.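

Compound 1 and compound 4 both end at a limit of this assay, not at a number, so no step between them can be read: the limit of > 100000 nM in this assay, at which 2 of the 4 values shown sit.

The compounds shown leave open whether bromo in place of iodo changes the tolerated concentration at all.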